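The source may hold more compounds than are shown below. What is called first, only, known or untested is meant among the compounds shown, and "the series" means these compounds.

Measured compounds in this series:
- Compound 1, `C/C=C1/[C@H](O[C@@H]2O[C@H](CO)[C@@H](O)[C@H](O)[C@H]2O)OC=C(C(=O)OC)[C@H]1CC(=O)NCCC`, gives > 20000 nM in a functional assay on SK-BR-3 cells (Homo sapiens) for antiproliferative activity, read by MTT assay, with a stated time of 72 h; a higher number here means a weaker inhibitor, a lower number a stronger inhibitor; this is a limit.
- Compound 2, `C/C=C1/[C@H](O[C@@H]2O[C@H](CO)[C@@H](O)[C@H](O)[C@H]2O)OC=C(C(=O)OC)[C@H]1CC(=O)OC`, gives > 15000 nM in this assay; this is a limit.
- Compound 3, `C=C(C)CCOC(=O)C[C@@H]1C(C(=O)OC)=CO[C@@H](O[C@@H]2O[C@H](CO)[C@@H](O)[C@H](O)[C@H]2O)/C1=C/C`, gives > 15000 nM in this assay; this is a limit.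

Compound 3 therefore stands only at a limit in this assay, and so do both other measured compounds. The single-point steps among them, a step that the two limits leave unreadable from compound 1 to compound 2, a step that the two limits leave unreadable from compound 1 to compound 3 and a step that the two limits leave unreadable from compound 2 to compound 3, are each left unreadable by the two limits, so no size or direction can be taken from any of them. For the measured compounds named here, the only evidence to hand is the limit of > 15000 nM in this assay, at which 2 of the 3 values shown sit, and (the limit of > 20000 nM in this assay, at which 1 of the 3 values shown sits).

Compound 4, `C/C=C1/[C@H](O[C@@H]2O[C@H](CO)[C@@H](O)[C@H](O)[C@H]2O)OC=C(C(=O)OC)[C@H]1CC(=O)OCCc1ccc(O)cc1`, differs from compound 3 at one place: 4-hydroxyphenyl in place of 1-methylethenyl on a saturated chain carbon, two bonds along the chain from an oxygen next to a carbonyl group. Going by the values given here, none of the measured steps bears readably on this change; what they show is that every variation so far on the saturated chain carbon bound to an oxygen next to a carbonyl group has left the value at a limit. The step expected in this assay from this change is a step that the limit leaves unreadable from compound 3 to compound 4, which is to say no readable movement from the limit is anticipated. Compound 4 is therefore estimated at 30000 nM, with a range from 8000 nM to 100000 nM, most probably reported again as a limit.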

Compound 4, half-maximal inhibitory concentration: > 20000 nM
Compound 4: only a limit was reported; the forecaster's own chance of this, stated with the estimate: 70%; the middle value is on the limit's open side.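

In this assay compound 4 gives > 20000 nM, which is a limit. Its steps from compound 1, compound 2 and compound 3 each join two limits, so none of them can be read. The compounds shown leave open whether any variation in this place gives a value in this assay that is not a limit.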